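The source may report more compounds than this note shows. Statements on the series, on what has been measured and on what is new or still open speak of the compounds shown alone.

In a functional assay on MCF7 cells (Homo sapiens) for cytotoxicity, read by MTT assay, with a stated time of 24 h (on this read-out lower numbers stand for stronger inhibition and higher numbers for weaker inhibition), compound 1 (`O=c1nc2ccccn2cc1Cc1ccc(F)cc1C(F)(F)F`) gives 9870 nM and holds the lowest of the two numbers. Within the data shown here, compound 3 (`O=c1nc2ccccn2cc1Cc1ccc(F)cc1`) gives 200000 nM and the only measured step is a 20-fold higher number from compound 1 to compound 3 (1.31 log units; beyond the scatter) with hydrogen in place of trifluoromethyl on an aromatic carbon. That step does not touch the site changing here. Compound 2 (`Cc1ccc(Cc2cn3cc(Cl)ccc3nc2=O)cc1`) carries chloro on the core and stands at > 1000000 nM in this assay and this is a limit. Compound 4 (`O=c1nc2ccc(Cl)cn2cc1Cc1ccc(F)cc1C(F)(F)F`) differs from compound 1 by chloro in place of hydrogen on an aromatic carbon with chloro in place of hydrogen on an aromatic carbon. Among the measured compounds shown here, no measured step isolates this change. The expected move is a modest rise, estimated as a 1.5-fold higher number from compound 1 to compound 4 (0.18 log units; within the scatter) with low confidence. Compound 4 is expected at 15000 nM with an estimated range of 3000 nM to 80000 nM as a working figure.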

Compound 4, half-maximal inhibitory concentration: 181000 nM
Compound 4: middle estimate off by 12-fold (1.08 log units), on the low side; the whole stated range lies below it.
By their numbers in this assay, from the lowest: compound 1; then compounds 4 and 3 (each within the scatter of the next). At a limit, above all of these: compound 2.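

Chloro in place of hydrogen on the core, two atoms from the ring nitrogen, gives an 18-fold higher number from compound 1 to compound 4 (1.26 log units; beyond the scatter) and so is not a neutral change. This position is therefore sensitive in this series, which the earlier step, made at the trifluoromethyl site, could not show. Compound 1 now loses much of its activity on a single change at either of two sites.

Going by these compounds, whether any group at this position would do the same stays open, and an amine or a methoxy group there would test it. The data shown give no cause for the step.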